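Cytotoxicity limits along the amide side-chain series

The source may report more compounds than this note shows. Statements on the series, on what has been measured and on what is new or still open speak of the compounds shown alone.

Compound 2 `CCC(=O)Nc1ccc(-c2nc3cc(C(F)(F)F)ccc3n2C)cc1` is judged in an ADME assay on Vero cells (Chlorocebus sabaeus) for cytotoxicity; a lower number here means that less compound is tolerated, a higher number that more compound is tolerated. Compound 2 reaches only the limit of the measurement, giving > 100000 nM, so no number is known for it. Compound 1 `CN1CCN(CC(=O)Nc2ccc(-c3nc4cc(C(F)(F)F)ccc4n3C)cc2)CC1` likewise stops at a limit with > 100000 nM. Going by the values given here, the only measured step, a step that the two limits leave unreadable from compound 1 to compound 2, cannot be read because of the limit of > 100000 nM in this assay, at which 2 of the 2 values shown sit. The next compound is compound 3 `Cn1c(-c2ccc(NC(=O)CN3CCCCC3)cc2)nc2cc(C(F)(F)F)ccc21`, which differs from compound 2 by piperidin-1-yl in place of methyl on a saturated chain carbon bound to a carbonyl carbon. This change returns toward the pattern of compound 1, a ring on the saturated chain carbon bound to a carbonyl carbon, and no measured value in this assay shows any movement away from the limit. Compound 3 is therefore expected to sit at the limit as well, with an expected step that the limit leaves unreadable from compound 2 to compound 3 that means nothing beyond the scatter. The estimate for compound 3 in this assay is 150000 nM, within a range from 60000 nM to 400000 nM.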

Compound 3, half-maximal cytotoxic concentration: > 100000 nM
Compound 3 gave a limit, no number (the forecaster's own chance of this, stated with the estimate: 85%); the middle value is on the limit's open side.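

Compound 3 also stops at a limit in this assay, so no step from compound 1 or compound 2 to compound 3 can be read: the limit of > 100000 nM in this assay, at which 3 of the 3 values shown sit.

The compounds shown leave open whether these amide side chains differ at all in this assay, since none has a numerical value.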